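A few compounds are considered here, and "the series" means these few. Any claim that something is new, unique, unknown or untested is made for them only; others in the source may bear on it.

Compound 1 `ClCc1ccccc1Cn1cnc2c(Cl)nc(Cl)nc21` and compound 2 `ClCc1cccc(Cn2cnc3c(Cl)nc(Cl)nc32)c1` are built from the same atoms joined differently, and the difference between the two cores is not broken down here. In a functional assay on MDA-MB-435 cells (Homo sapiens) for cytotoxicity, read by sulforhodamine B assay, with a stated time of 48 h (a lower number here means a stronger inhibitor of growth, a higher number a weaker inhibitor of growth), compound 1 gives 3230 nM. In this assay compound 2 gives 3230 nM, level with compound 1 at the digits printed and within the usual scatter of it.

Compound 3 `Nc1nc(Cl)c2ncn(Cc3ccccc3CCl)c2n1` is reached from compound 1 by one change, (amino in place of chloro on an aromatic carbon). In this assay compound 3 gives 26900 nM, and the step is an 8.3-fold higher number from compound 1 to compound 3 (0.92 log units; beyond the scatter), a modest but real weakening of growth inhibition.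

Compound 4 `Nc1nc(Cl)c2ncn(Cc3cccc(CCl)c3)c2n1` has not yet been measured. It is reached from compound 2 by the same change, (amino in place of chloro on an aromatic carbon), and the two place descriptions agree word for word. The step from compound 2 to compound 4 in this assay is therefore expected to be an 8.3-fold higher number from compound 2 to compound 4 (0.92 log units; beyond the scatter), an expectation that rests on the step of an 8.3-fold higher number from compound 1 to compound 3 (0.92 log units; beyond the scatter) seen for compound 1. On that basis compound 4 is estimated to give 26900 nM in this assay, with a likely range from 11000 nM to 65000 nM.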

Compound 4, concentration for total growth inhibition: 22400 nM
Compound 4: the middle estimate sits 1.2-fold (0.08 log units) above what was measured; the range from low to high includes it.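

Putting amino in place of chloro on the aromatic carbon between two ring nitrogen atoms also weakens growth inhibition on the core of compound 2 in this assay, giving a 6.9-fold higher number from compound 2 to compound 4 (0.84 log units; beyond the scatter). Set beside the earlier step, the change carries over from one core to the other at much the same size: the same change on two cores in this assay, an 8.3-fold higher number (0.92 log units; beyond the scatter) from compound 1 to compound 3 and a 6.9-fold higher number (0.84 log units; beyond the scatter) from compound 2 to compound 4, 1.2-fold (0.08 log units) apart, within the scatter of two such steps. Going by these compounds alone, this shows that the step transfers between these two cores in this one assay, but with only two pairs it does not show why the step has this size, or that it would hold on any other core.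

The compounds shown carry only chloro or amino at this place, so it remains open how a methylamino group, a methoxy group or a plain hydrogen there would behave. They also leave open what a hydroxymethyl group or a longer chain would do in place of the chloromethyl group.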